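From Methoxy to Bromo: One Small Swap

This account rests on a few compounds, and the source may have more. Where it says the series, first, only, none or still open, it means among the compounds named here.

In a physicochemical assay for inhibition, with a stated time of 7 days (a higher number here means a weaker inhibitor, a lower number a stronger inhibitor), compound 1 `COc1ccc(NC(=O)Nc2cccc(Cl)c2)cc1` gives 7140 nM and compound 2 `O=C(Nc1cccc(Cl)c1)Nc1cccc(Br)c1` gives 8160 nM so the two stand level, within the scatter of each other. Compound 3 `O=C(Nc1ccc(Br)cc1)Nc1cccc(Cl)c1` has not yet been measured. It differs from compound 1 by a single swap bromo in place of methoxy on an aromatic carbon with bromo in place of methoxy on an aromatic carbon, para to a large group. Compound 2 also carries a bromo group and gives 8160 nM so no shift beyond the scatter is expected in either direction. The estimated step of a 1.2-fold lower number from compound 1 to compound 3 (0.08 log units; within the scatter) is therefore small. In this assay compound 3 is expected at 6000 nM with a likely range from 2500 nM to 14000 nM around that estimate.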

Compound 3, half-maximal inhibitory concentration: 6400 nM
Beside the measured number, compound 3's estimate is 1.1-fold (0.03 log units) below it; the measured number falls inside the stated range.
By their numbers in this assay, from the lowest: compounds 3, 1 and 2 (each within the scatter of the next).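

For the compounds shown here, this is the first pair of compounds that differ in one place only, so the position can now be read directly. In this assay, putting bromo in place of methoxy, para to a large group, gives a 1.1-fold lower number from compound 1 to compound 3 (0.05 log units; within the scatter). In this one pair, then, losing the hydrogen-bond acceptor of methoxy and one heavy atom leaves the number level. No measurement here bears on why the two groups stand level. As far as these compounds go, whether an amine, a carboxylic acid or a longer chain at this position would also stay level remains open.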